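The source may report more compounds than this note shows. Statements on the series, on what has been measured and on what is new or still open speak of the compounds shown alone.

Of the compounds shown here, two sharing one core have been measured so far. Compound 2 `COc1cc2c(Oc3ccc(NC(=O)c4cc(-c5ccc(C)cc5)ccn4)cc3F)ccnc2cc1OCCCN1CCCC1` was tested in a functional assay on NCI-H460 cells (Homo sapiens) for cytotoxicity, read by MTT assay, with a stated time of 72 h (a higher number here means a weaker inhibitor, a lower number a stronger inhibitor), and in that assay compound 2 gives 160 nM. Among the compounds with values here, its companion, compound 1 `COc1cc2c(Oc3ccc(NC(=O)c4cc(-c5ccc(C(F)(F)F)cc5)ccn4)cc3F)ccnc2cc1OCCCN1CCCCC1`, differs from compound 2 in more than one place, so no single structural step connects them; in this assay compound 1 gives 360 nM. Within the data shown here, of the two numbers available, the one for compound 2 is the lower, and the gap up to compound 1 lies beyond the usual scatter of repeated measurements.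

The next compound, compound 3 `COc1ccc(-c2ccnc(C(=O)Nc3ccc(Oc4ccnc5cc(OCCCN6CCCC6)c(OC)cc45)c(F)c3)c2)cc1`, is built from compound 2 by a single change, namely (methoxy in place of methyl on an aromatic carbon), in words: methoxy in place of methyl on an aromatic carbon. Among the measured compounds shown here, no measured pair of compounds here shows that same change, so there is no step on record to lean on. With only one atom added at the outer edge of the molecule, the step from compound 2 to compound 3 is expected to be small, a 1.1-fold higher number from compound 2 to compound 3 (0.05 log units; within the scatter), and most likely to fall within the scatter in either direction. On that basis compound 3 is estimated to give about 180 nM, with a likely range from 70 nM to 450 nM.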

Compound 3, half-maximal inhibitory concentration: 200 nM
Beside the measured number, compound 3's estimate is 1.1-fold (0.05 log units) below it, within the range that was stated.
By their numbers in this assay, from the lowest: compounds 2, 3 and 1 (each within the scatter of the next, the first and the last beyond it).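

Swapping methyl for methoxy on this aromatic carbon, para to a large group, gives a 1.3-fold higher number from compound 2 to compound 3 (0.10 log units; within the scatter) in this assay. Within the data shown here, this is the first single-place comparison, since compound 1 could not be linked to compound 2 by one step. It shows that, for this pair, the position takes the slightly larger methoxy group, with its oxygen and added hydrogen-bond acceptor, without a difference that can be told apart from repeat-measurement noise, although one pair cannot show how far that tolerance extends; no measurement shown here explains why the two groups read alike.

Still open, as far as these compounds go, is how this position responds to groups of a different kind, such as an amine, a carboxylic acid or a longer alkoxy chain placed there with the rest of compound 2 unchanged. Compound 1 differs from compound 2 in more than one place, trifluoromethyl among them, so the gap between those two compounds cannot be credited to this position alone.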